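Lengthening a Chain on a Weak Cortical Neurone Inhibitor

This account rests on a few compounds, and the source may have more. Where it says the series, first, only, none or still open, it means among the compounds named here.

Compound 1, `CCCCCc1nc2[nH]c(-c3ccc(Cl)cc3)cc(=O)n2n1`, carries a saturated chain on the shared core. In a functional assay on Cortical neurone cells (Mus musculus, strain C57BL/6), read by FLIPR and calcium flux, with a stated time of 8 min (on this read-out lower numbers stand for stronger inhibition and higher numbers for weaker inhibition), compound 1 gives 8250 nM, the highest of the three numbers measured here, which means the weakest inhibition of the three. Compound 2, `Cc1ccc(-c2nc3[nH]c(-c4ccccc4)cc(=O)n3n2)cc1`, gives 3210 nM and compound 3, `O=c1cc(-c2ccccc2)[nH]c2nc(Cc3ccc(Cl)cc3)nn12`, gives 1830 nM; both lie beyond the scatter from compound 1. Among the compounds with values here, the only measured step between two compounds that differ in a single place, a 1.8-fold lower number from compound 2 to compound 3 (0.24 log units; within the scatter), stays within the scatter.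

Compound 4, `CCCCCCc1nc2[nH]c(-c3ccc(Cl)cc3)cc(=O)n2n1`, differs from compound 1 by methyl in place of hydrogen on a saturated chain carbon, five bonds along the chain from an aromatic carbon. Within the data shown here, none of the measured compounds probes a change of this kind: the step from compound 2 to compound 3 swaps 4-methylphenyl for 4-chlorobenzyl, and nothing here varies the length of the saturated chain. Among the measured compounds shown here, there is thus no measured step to lean on, and the only guide is that the single recorded step was small. The expectation for compound 4 is therefore no movement in this assay beyond the scatter, an estimated step of a 1.0-fold lower number from compound 1 to compound 4 (0.01 log units; within the scatter). Compound 4 is accordingly expected at about 8000 nM, with a likely range from 3500 nM to 19000 nM.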

Compound 4, half-maximal inhibitory concentration: 8720 nM
Beside the measured number, compound 4's estimate is 1.1-fold (0.04 log units) below it; the range from low to high includes it.
By their numbers in this assay, from the lowest: compounds 3 and 2 (each within the scatter of the next); then compounds 1 and 4 (each within the scatter of the next).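

Within the data shown here, the step of a 1.1-fold higher number from compound 1 to compound 4 (0.02 log units; within the scatter) in this assay is the first measured change on the saturated chain, the part of compound 1 that none of the earlier comparisons touched. It shows that methyl in place of hydrogen on a saturated chain carbon, five bonds along the chain from an aromatic carbon, leaves the number where it was, as far as this read-out can tell. This is a single step, so it speaks for this one added carbon only and does not establish a trend with chain length, and nothing on hand explains why the change has so little effect.

The compounds shown leave open whether a shorter chain such as propyl, a much longer chain such as decyl, or a chain ending in an amine or a carboxylic acid would shift the number beyond the scatter. They also leave open whether a ring such as phenyl placed at the far end of the chain would give a larger step than this one.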